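The source may hold more compounds than are shown below. What is called first, only, known or untested is meant among the compounds shown, and "the series" means these compounds.

Three analogues on a shared core have been run in a functional assay on the whole organism (stomach) for inhibition, with Rattus norvegicus as the target, at a dose of 100 mg/kg by the intraduodenal route; a higher number here means more inhibition at the dose given (going by the name of the read-out), a lower number less inhibition. Compound 3 `C/N=C(/S)CCCCCn1nc(-c2ccccc2)ccc1=O` gives 92.3%, the highest of the three measured numbers; compound 1 `C/N=C(\S)CCn1nc(-c2ccccc2)ccc1=O` gives 68.2%, and compound 2 `N=C(S)CCCCCCn1nc(-c2ccccc2)ccc1=O` gives 33.9%. The gap a number 24.1 percentage points higher from compound 1 to compound 3 (beyond the scatter) and the gap a number 58.4 percentage points higher from compound 2 to compound 3 (beyond the scatter) both lie beyond the scatter, as does a number 34.3 percentage points lower from compound 1 to compound 2 (beyond the scatter).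

Compound 4 `CN(C)C(=S)CCn1nc(-c2ccccc2)ccc1=O` has not yet been measured. Relative to compound 3 the change is a group of 5 heavy atoms (3 carbon, 1 nitrogen, 1 sulfur; no ring) in place of a group of 7 heavy atoms (5 carbon, 1 nitrogen, 1 sulfur; no ring), on a saturated chain carbon, two bonds along the chain from an aromatic nitrogen. It returns the chain to the length present in compound 1, while the terminal group itself also differs from that of compound 1. The measured step bearing most directly on this is a number 24.1 percentage points higher from compound 1 to compound 3 (beyond the scatter), at the same place on the chain; compound 4 undoes that extension, so a fall of comparable size is expected in this assay. Within the data shown here, the terminal-group difference between compound 1 and compound 4 has no measured counterpart at this chain length; the only measured change of a terminal group at fixed length is a number 58.4 percentage points higher from compound 2 to compound 3 (beyond the scatter), at a different place, and it was large, which widens the uncertainty. A modest to large fall is therefore expected. Compound 4 is estimated at 60%, within 35% to 85%. The implied step, a number 32.3 percentage points lower from compound 3 to compound 4 (beyond the scatter), is expected to lie beyond the scatter.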

Compound 4, a percentage reported as inhibition, in the whole organism at one dose (the size of the read-out at that dose, not a potency): 46%
Beside the measured number, compound 4's estimate is 14 percentage points above it, within the range that was stated.
By their numbers in this assay, from the lowest: compound 2; then compound 4; then compound 1; then compound 3.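

In this assay the fall a number 46.3 percentage points lower from compound 3 to compound 4 (beyond the scatter) is the largest step yet seen on moving away from compound 3 at this place on the chain, two bonds along from an aromatic nitrogen, and it shows how much the response depends on the chain and terminal group together. Among these compounds, at the shorter chain, the step of a number 22.2 percentage points lower from compound 1 to compound 4 (beyond the scatter) is the first reading of a terminal-group change at this length: the group entering compound 4 has 0 hydrogen-bond donors where the group it replaces in compound 3 has 1, and the change from the terminal group of compound 1 is not neutral. The step of a number 12.1 percentage points higher from compound 2 to compound 4 (beyond the scatter) keeps compound 4 clear of the lowest compound, so this terminal group on the shorter chain still retains part of the response.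

The compounds shown leave open how the terminal group of compound 4 behaves on the longer chain of compound 3, and whether a carboxamide or a pyrrolidine-capped thioamide at the chain end would track compound 1 or compound 4. Each number is the size of an effect at one dose, so the order says nothing about potency, and nothing at hand gives a reason for these steps.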